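Carbamate on the ring oxygen of compound 1

A few compounds are considered here, and "the series" means these few. Any claim that something is new, unique, unknown or untested is made for them only; others in the source may bear on it.

Compound 1 `CC(C)=CCC1Cc2c(O)cc(=O)n(CCCO)c2CC1(C)C` gives 25.6% in a functional assay on PANC-1 cells (Homo sapiens) for inhibition, read by MTT assay, with a stated time of 24 h, tested at 10 uM (on this read-out higher numbers stand for more inhibition at the one concentration tested (going by the name of the read-out) and lower numbers for less inhibition), the second highest of three numbers, with both others within the scatter. Compound 2 `CC(C)=CCC/C(C)=C/CC1Cc2c(O)cc(=O)n(CCCO)c2CC1(C)C` gives 28.7% in this assay, and compound 3 `CC(C)=CCC1Cc2c(OCCCOc3ccc(Cl)cc3)cc(=O)n(CCCO)c2CC1(C)C` gives 22.7%; the steps of a number 3.1 percentage points higher from compound 1 to compound 2 (within the scatter) and a number 2.9 percentage points lower from compound 1 to compound 3 (within the scatter) both stay within the scatter.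

Compound 4 `CC(C)=CCC1Cc2c(OC(=O)Nc3ccccc3F)cc(=O)n(CCCO)c2CC1(C)C` has not yet been measured. Its change from compound 1 is (2-fluorophenyl)carbamoyl in place of hydrogen on an oxygen on an aromatic ring. The step bearing on it is the one that also replaces hydrogen on the same oxygen, a number 2.9 percentage points lower from compound 1 to compound 3 (within the scatter), which lay within the scatter; the step of a number 3.1 percentage points higher from compound 1 to compound 2 (within the scatter) sits elsewhere on the core. A step of a number 0.6 percentage points lower from compound 1 to compound 4 (within the scatter) of no size beyond the scatter is therefore expected. Compound 4 is estimated at 25%, with a range from 12% to 38%.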

Compound 4, a percentage reported as inhibition, at one concentration (the size of the read-out at that concentration, not a potency): 52.3%
The estimate for compound 4 lay 27.3 percentage points below the measured number, outside the stated range (above it).
By their numbers in this assay, from the lowest: compounds 3, 1 and 2 (each within the scatter of the next); then compound 4.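

On the oxygen on an aromatic ring, (2-fluorophenyl)carbamoyl in place of hydrogen gives in this assay a step that is a number 26.7 percentage points higher from compound 1 to compound 4 (beyond the scatter) and so shows that this position can respond, which the earlier step there did not show. The exchange of 3-(4-chlorophenoxy)propyl for (2-fluorophenyl)carbamoyl on the same oxygen is a number 29.6 percentage points higher from compound 3 to compound 4 (beyond the scatter) and shows that the response depends on the group that enters. No measurement at hand explains the gain.

Still open, going by these compounds, is whether a plain phenylcarbamoyl or an acetyl group on this oxygen would give a step of similar size, which would help separate the contribution of the fluorine from that of the carbonyl link.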